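This account rests on a few compounds, and the source may have more. Where it says the series, first, only, none or still open, it means among the compounds named here.

Measured compounds:
compound 1 `O=C(NO)c1cccc(-c2cn([C@H]3C[C@H](C(=O)O)N(Cc4ccccc4)C3)nn2)c1`: < 10%
compound 2 `O=C(/C=C/c1cn([C@H]2C[C@H](C(=O)O)N(Cc3ccccc3)C2)nn1)NO`: 14%

In an assay on Sf9 cells for inhibition of histone deacetylase 11 (Homo sapiens), read by fluorescence, tested at 0.5 uM (on this read-out lower numbers stand for less inhibition and higher numbers for more inhibition at the one concentration tested (going by the name of the read-out)), compound 1 gives only a limit, < 10%, not a number. In this assay compound 2 gives 14%. Among the compounds with values here, the one measured step, a number at least 4 percentage points higher from compound 1 to compound 2 (that floor lies within the scatter), rests on the limit of < 10% in this assay, at which 1 of the 2 values shown sits, and stays within the scatter, so it sets no clear trend.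

Within the data shown here, compound 3 `O=C(NO)c1cccc(-c2cn([C@@H]3C[C@@H](C(=O)O)N(Cc4ccccc4)C3)nn2)c1` is the unmeasured compound. the two compounds have the same atoms and bonds and differ only in configuration as drawn: 2 of 2 stereo elements differ (all stereocentres are inverted: mirror images); a stereocentre at a saturated ring carbon is drawn S in compound 1 and R in compound 3; a stereocentre at a saturated ring carbon is drawn R in compound 1 and S in compound 3 That change, inverting both stereocentres, has no counterpart among the measured steps; the step from compound 1 to compound 2 alters a substituent, not configuration, and bears on it only in showing that compound 1 sits at the limit with little room to fall. As compound 1 is known only as a limit, the step for compound 3, a number no lower from compound 1 to compound 3 (the limit leaves the size open), is expected to be small and most likely within the scatter. Compound 3 is expected to give about 10% in this assay, with a range of 0% to 30%, and a fair chance that only a limit is again reported.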

Compound 3, a percentage reported as inhibition, at one concentration (the size of the read-out at that concentration, not a potency): < 10%
Compound 3 ended at the assay's limit (the forecaster's own chance of this, stated with the estimate: 50%); the middle value sits exactly at the limit.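

In this assay compound 3 gives < 10% which is a limit and not a number. Within the data shown here, no step from compound 1 to compound 3 can be read, because both compounds stand at the same limit: the limit of < 10% in this assay, at which 2 of the 3 values shown sit.
Left open is whether the two mirror images differ at all in this assay at a level the limit hides: the fact that compounds 1 and 3 differ only in the configuration as drawn.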